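The compounds below may be only part of what the source reports. "The series", "measured", "known", "first", "only" and "open" are said of these compounds alone.

Measured in a functional assay on M21 cells (Homo sapiens) for antiproliferative activity, read by sulforhodamine B assay, with a stated time of 48 h; on this read-out higher numbers stand for weaker inhibition and lower numbers for stronger inhibition:
- compound 1 `CCCN1CCN(c2ccc(S(=O)(=O)Oc3ccccc3OC)cc2)C1=O`: > 100000 nM, a limit of the assay
- compound 2 `CCCN1CCN(c2ccc(S(=O)(=O)Oc3cccc(OC)c3)cc2)C1=O`: 10000 nM
- compound 3 `CCCN1CCN(c2ccc(S(=O)(=O)Oc3cccc([N+](=O)[O-])c3)cc2)C1=O`: 38000 nM

Of the two values that are actual numbers, the higher belongs to compound 3. Compound 4 `CCCN1CCN(c2ccc(S(=O)(=O)Oc3ccc(OC)cc3)cc2)C1=O` carries 4-methoxyphenyl in place of 3-nitrophenyl on an oxygen. For the measured compounds named here, two measured steps bear on this change. Nitro in place of methoxy on an aromatic carbon gave a 3.8-fold higher number from compound 2 to compound 3 (0.58 log units; beyond the scatter), which points to a lower number on returning to methoxy. Moving the methoxy, 3-methoxyphenyl in place of 2-methoxyphenyl, gave an at least 10-fold lower number from compound 1 to compound 2 (1.00 log units; beyond the scatter), so its place can matter at least as much, and no measured compound carries 4-methoxyphenyl. A modest drop is therefore expected, a 2.5-fold lower number from compound 3 to compound 4 (0.40 log units; beyond the scatter), though with wide uncertainty. For compound 4 the estimated value is 15000 nM, with an expected range of 4000 nM to 60000 nM.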

Compound 4, half-maximal inhibitory concentration: 23000 nM
Compound 4: middle estimate off by 1.5-fold (0.19 log units), on the low side; the range from low to high includes it.
By their numbers in this assay, from the lowest: compound 2; then compounds 4 and 3 (each within the scatter of the next). At a limit, above all of these: compound 1.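

Compound 4 completes the three methoxyphenyl groups on the oxygen bound to the sulfonyl sulfur, and 3-methoxyphenyl keeps the stronger inhibition over 4-methoxyphenyl (a 2.3-fold higher number from compound 2 to compound 4 (0.36 log units; beyond the scatter)). 4-Methoxyphenyl and 3-nitrophenyl cannot be told apart here (a 1.7-fold lower number from compound 3 to compound 4 (0.22 log units; within the scatter)). The step from 2-methoxyphenyl (an at least 4.3-fold lower number from compound 1 to compound 4 (0.63 log units; beyond the scatter)) has no fixed size, since compound 1 stands at a limit: the limit of > 100000 nM in this assay, at which 1 of the 4 values shown sits.

Still open, on these data alone, is whether an amine or a carboxylic acid on that phenyl ring, or a longer chain on the shared core, would give a lower number than compound 2 has.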